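Urea to amide on the trifluoromethylphenyl arm

This account rests on a few compounds, and the source may have more. Where it says the series, first, only, none or still open, it means among the compounds named here.

Measured compounds:
compound 1 `COc1cc(Cl)cc(-c2nn(-c3cccc(NC(=O)c4ccc(Cl)c(Cl)c4)c3)cc2-c2ccncc2)c1` — 87.8%
compound 2 `COc1cc(Cl)cc(-c2nn(-c3cccc(NC(=O)Nc4ccc(Cl)c(Cl)c4)c3)cc2-c2ccncc2)c1` — 23.2%
compound 3 `COc1cc(Cl)cc(-c2nn(-c3cccc(NC(=O)Nc4cccc(C(F)(F)F)c4)c3)cc2-c2ccncc2)c1` — 14.1%

All three share one core and differ only in the group attached to the carbonyl carbon of the side-chain amide. In a functional assay on SK-MEL-28 cells (Homo sapiens) for inhibition, read by sulforhodamine B assay, with a stated time of 48 h, tested at 10 uM (on this read-out higher numbers stand for a weaker effect at the one concentration tested and lower numbers for a stronger effect), compound 3 gives the lowest of the three numbers, but its step to compound 2, a number 9.1 percentage points lower from compound 2 to compound 3 (within the scatter), is within the scatter, so the two cannot be ordered; only compound 1 stands clearly apart, as a number 73.7 percentage points lower from compound 1 to compound 3 (beyond the scatter) shows.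

Compound 4 `COc1cc(Cl)cc(-c2nn(-c3cccc(NC(=O)c4cccc(C(F)(F)F)c4)c3)cc2-c2ccncc2)c1` is compound 3 with 3-(trifluoromethyl)phenyl in place of (3-(trifluoromethyl)phenyl)amino on a carbonyl carbon. This is the reverse of the change seen in a number 64.6 percentage points lower from compound 1 to compound 2 (beyond the scatter), where the urea in place of the amide went with a large drop; a number 73.7 percentage points lower from compound 1 to compound 3 (beyond the scatter) points the same way. A large rise in this assay is therefore expected for compound 4, roughly undoing that drop, with a number 65.9 percentage points higher from compound 3 to compound 4 (beyond the scatter) as the expected step. The estimate for compound 4 is 80%, in the range 55% to 97%.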

Compound 4, a percentage reported as activity, at one concentration (the size of the read-out at that concentration, not a potency): 70.4%
Compound 4: middle estimate off by 9.6 percentage points, on the high side, and the stated range covers the measured number.
By their numbers in this assay, from the lowest: compounds 3 and 2 (each within the scatter of the next); then compound 4; then compound 1.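

In this assay the link between urea and amide now holds on the trifluoromethylphenyl arm as well, with a number 56.3 percentage points higher from compound 3 to compound 4 (beyond the scatter) and a number 47.2 percentage points higher from compound 2 to compound 4 (beyond the scatter) both matching in direction the large steps seen from the amide compound 1 to the two ureas. The aryl group also begins to count on the amide side, as a number 17.4 percentage points lower from compound 1 to compound 4 (beyond the scatter) is a modest step, whereas the same swap between the ureas stays within the scatter. Nothing measured here explains either step.

Going by these compounds, it remains open whether a thiourea, a carbamate or a urea with a methyl group on the amide-type nitrogen would fall with the ureas or with the amides. At the single concentration tested, the ureas also cannot be ordered by the strength of their effect.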